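The source may report more compounds than this note shows. Statements on the series, on what has been measured and on what is new or still open speak of the compounds shown alone.

The compounds measured so far, each in a functional assay on MCF7 cells (Homo sapiens) for cytotoxicity, read by MTT assay, with a stated time of 48 h; on this read-out lower numbers stand for stronger inhibition and higher numbers for weaker inhibition:

Compound 1, `COc1cc(-c2nnc3n2NC(c2ccco2)C(C(=O)c2ccccc2C)S3)cc(OC)c1OC`, gives 69900 nM.
Compound 2, `COc1cc(-c2nnc3n2NC(c2ccco2)C(C(=O)c2ccc(Br)cc2)S3)cc(OC)c1OC`, gives only a limit of the assay, > 100000 nM.
Compound 3, `COc1cc(-c2nnc3n2NC(c2ccco2)C(C(=O)c2ccc(Cl)cc2)S3)cc(OC)c1OC`, gives only a limit of the assay, > 100000 nM.

Compound 2 thus stands at the upper edge of what this assay reports, a point described by the limit of > 100000 nM in this assay, at which 2 of the 3 values shown sit, and it shares that position with compound 3; no number separates the two. The compound still to be measured is compound 4, `COc1cc(-c2nnc3n2NC(c2ccco2)C(C(=O)c2ccc(F)cc2)S3)cc(OC)c1OC`. It differs from compound 2 by fluoro in place of bromo on an aromatic carbon.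

Among the compounds with values here, two measured steps bear on this change. Replacing the 2-methylphenyl of compound 1 gave an at least 1.4-fold higher number from compound 1 to compound 2 (0.15 log units; that floor lies within the scatter) and an at least 1.4-fold higher number from compound 1 to compound 3 (0.15 log units; that floor lies within the scatter), both landing at the limit. Swapping one halogen for another within that pair gave a step that the two limits leave unreadable from compound 2 to compound 3, so the halogen swap itself left no readable trace. A third halogen in the same position is therefore expected to move the number little, if at all, beyond the scatter, with compound 4 expected to sit near the limit as well, a step that the limit leaves unreadable from compound 2 to compound 4 from compound 2.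

The estimate for compound 4 in this assay is 150000 nM, within a range from 50000 nM to 500000 nM.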

Compound 4, half-maximal inhibitory concentration: > 100000 nM
Compound 4 gave a limit, no number (the forecaster's own chance of this, stated with the estimate: 70%); the middle value is on the limit's open side.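

Compound 4 gives > 100000 nM in this assay, which is a limit of the assay and not a number, so fluoro on the 4-fluorophenyl carbonyl joins bromo and chloro at the same place on the ring without producing a readable value. Within the data shown here, replacing the 2-methylphenyl of the one compound with a measured number gives an at least 1.4-fold higher number from compound 1 to compound 4 (0.15 log units; that floor lies within the scatter), so this third halogen, like the other two, shows no separation from compound 1 that clears the usual scatter. The steps among compound 2, compound 3 and compound 4 cannot be read, and what the new result adds is that the whole halogen set, from bromine down to fluorine, now rests at one edge of this assay: the limit of > 100000 nM in this assay, at which 3 of the 4 values shown sit.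

Whether the three halogens truly differ from one another stays hidden, since a limit gives no number to compare, and a measurement reaching further up the concentration scale would be needed to tell them apart. As far as these compounds go, it also remains open whether a group of another kind at this place on the ring, such as an amine, a methoxy group or a carboxylic acid, would bring the number back into the readable range.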